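Replacing a urea link by an amide

A few compounds are considered here, and "the series" means these few. Any claim that something is new, unique, unknown or untested is made for them only; others in the source may bear on it.

Compound 2 `O=C(Nc1ccc(-n2cc(-c3ccncc3)c(-c3ccc(Cl)c(O)c3)n2)cc1)Nc1ccc(Cl)c(C(F)(F)F)c1` shows the lowest of the two numbers in a functional assay on SK-MEL-28 cells (Homo sapiens) for antiproliferative activity, read by sulforhodamine B assay, with a stated time of 48 h (on this read-out higher numbers stand for weaker inhibition and lower numbers for stronger inhibition), giving 1630 nM, though compound 1 `COc1cc(-c2nn(-c3ccc(NC(=O)Nc4ccc(Cl)c(C(F)(F)F)c4)cc3)cc2-c2ccncc2)ccc1Cl` with 1880 nM lies within the scatter of it, as a 1.2-fold lower number from compound 1 to compound 2 (0.06 log units; within the scatter) describes. Compound 3 `O=C(Nc1ccc(-n2cc(-c3ccncc3)c(-c3ccc(Cl)c(O)c3)n2)cc1)c1ccc(Cl)c(C(F)(F)F)c1` differs from compound 2 by 4-chloro-3-(trifluoromethyl)phenyl in place of (4-chloro-3-(trifluoromethyl)phenyl)amino on a carbonyl carbon. Within the data shown here, no measured step touches this carbonyl carbon; the only step known concerns an oxygen elsewhere, so it gives no guide. Compound 3 is therefore expected near 4000 nM, within 1000 nM to 16000 nM, a step of a 2.5-fold higher number from compound 2 to compound 3 (0.39 log units; beyond the scatter) that carries wide uncertainty.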

Compound 3, half-maximal inhibitory concentration: 1080 nM
Beside the measured number, compound 3's estimate is 3.7-fold (0.57 log units) above it, within the range that was stated.
By their numbers in this assay, from the lowest: compounds 3, 2 and 1 (each within the scatter of the next).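

Among these compounds, this is the first measured step at the carbonyl carbon. In this assay, 4-chloro-3-(trifluoromethyl)phenyl in place of (4-chloro-3-(trifluoromethyl)phenyl)amino gives a 1.5-fold lower number from compound 2 to compound 3 (0.18 log units; within the scatter), so the link's nitrogen and its hydrogen-bond donor can go without a difference this read-out can separate from repeat-measurement scatter. Nothing available explains this result. Going by these compounds, what a methylamino group or a longer alkyl chain on this carbonyl carbon would give remains open. Also open, on these data alone, is whether the amide of compound 3 would hold up with a carboxylic acid on the aromatic ring in place of chlorine.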